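The compounds below may be only part of what the source reports. "The series", "measured", "known", "first", "only" and "open" are said of these compounds alone.

Measured compounds in the series:
- compound 1, `O=C(CN1CCN(c2cccc(F)c2)CC1)Nc1nc2c(s1)CCCC2`: > 10000 nM
- compound 2, `O=C(CN1CCN(c2ccc(F)cc2)CC1)Nc1nc2c(o1)CCCC2`: 5400 nM

Working notes. In an assay on isolated protein for inhibition of long-chain fatty acid transport protein 1 (Mus musculus), read by scintillation counting, with a stated time of 20 min (a higher number here means a weaker inhibitor, a lower number a stronger inhibitor), compound 1 gives only a limit, > 10000 nM; the value is an assay limit and not a number. In this assay compound 2 gives 5400 nM. Compound 1 and compound 2 differ in more than one place, so their two values are taken only as they stand: one at the limit (the limit of > 10000 nM in this assay, at which 1 of the 2 values shown sits), the other a measured number in the weak range.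

The unmeasured compound 3, `O=C(CN1CCN(c2ccc(F)cn2)CC1)Nc1nc2c(s1)CCCC2`, differs from compound 1 in one place: 5-fluoropyridin-2-yl in place of 3-fluorophenyl on an amine nitrogen in a ring. Among the measured compounds shown here, no comparable step between measured compounds exists in this set, so the direction of the change is open. With compound 1 sitting at the limit (the limit of > 10000 nM in this assay, at which 1 of the 2 values shown sits), any move toward weaker inhibition would again be reported only as a limit, and only a clear gain would yield a number.

Expectation: compound 3 is estimated at 12000 nM in this assay, with a range of 3000 nM to 40000 nM. The expected step from compound 1 to compound 3 is a step that the limit leaves unreadable from compound 1 to compound 3, which is not expected to exceed the usual scatter, and a further limit-only result is considered about as likely as a measured number.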

Compound 3, half-maximal inhibitory concentration: 600 nM
Compound 3: the middle estimate sits 20-fold (1.30 log units) above what was measured, outside the stated range (below it).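

In this assay, the aryl group on the amine nitrogen in a ring proves able to lift the series off the limit: 5-fluoropyridin-2-yl in place of 3-fluorophenyl gives an at least 16-fold lower number from compound 1 to compound 3 (1.22 log units; beyond the scatter). Compound 1 gives only an assay limit, > 10000 nM, so the true size of this step cannot be read and the printed size is a minimum: the limit of > 10000 nM in this assay, at which 1 of the 3 values shown sits. The heavy-atom count stays at 7 while the entering ring gains 1 hydrogen-bond acceptor, yet this single step does not separate the effect of the ring nitrogen from that of the different fluorine placement in the two groups.

As far as these compounds go, it remains open whether the gain needs the fluorine at all, which a plain pyridin-2-yl group would test, and whether a second ring nitrogen, as in a 5-fluoropyrimidin-2-yl group, would extend it. Also open, from the compounds shown here alone, is whether 5-fluoropyridin-2-yl brings a similar gain on the core of compound 2, which differs from compound 3 in more than one place.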